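The source may report more compounds than this note shows. Statements on the series, on what has been measured and on what is new or still open speak of the compounds shown alone.

For the measured compounds named here, compound 2 `COc1ccc(/C=C/c2cc(=O)cco2)cc1` is one of only two compounds measured in an ADME assay on HaCaT cells (Homo sapiens) for inhibition, read by sulforhodamine B assay, with a stated time of 48 h; a lower number here means a stronger inhibitor of growth, a higher number a weaker inhibitor of growth; in that assay compound 2 gives 710 uM. Compound 1 `O=c1ccoc(/C=C/c2ccccc2)c1`, the other measured compound, gives 711 uM in this assay, and the step of a 1.0-fold lower number from compound 1 to compound 2 (0.00 log units; within the scatter) shows that placing a methoxy group on the aromatic ring left the number unchanged within the scatter. Compound 3 `COc1ccc(/C=C/c2cc(=O)cco2)cc1OC` differs from compound 2 by methoxy in place of hydrogen on an aromatic carbon, the new group sitting ortho to a methoxy group already present. Going by the values given here, the only measured step that bears on this change is a 1.0-fold lower number from compound 1 to compound 2 (0.00 log units; within the scatter), which was within the scatter. On that basis no step beyond the scatter is expected in this assay, in either direction. Compound 3 is therefore estimated at 700 uM, with a range from 400 uM to 1200 uM. The expected step of a 1.0-fold lower number from compound 2 to compound 3 (0.01 log units; within the scatter) is essentially none.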

Compound 3, concentration for growth inhibition (reported as GI): 690 uM
Compound 3: middle estimate off by 1.0-fold (0.01 log units), on the high side; the measured number falls inside the stated range.
By their numbers in this assay, from the lowest: compounds 3, 2 and 1 (each within the scatter of the next).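

In this assay, the step for the added methoxy group is a 1.0-fold lower number from compound 2 to compound 3 (0.01 log units; within the scatter). The earlier step showed this replacement only on a ring with no methoxy group already present, whereas here the same replacement, at a position ortho to a methoxy group and meta to a group of 9 heavy atoms, also stays within the scatter. No measurement bears on why this replacement produces no step beyond the scatter at either place.

On these data alone, it remains open whether a hydroxyl group or an amine at this position, or a longer chain such as ethoxy in place of the methoxy, would give a step beyond the scatter. Because neither step shown lies beyond the scatter, the compounds also leave open which parts of the ring, if any, respond to substitution in this assay.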